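Selenium-ring nucleoside analogues: the azido to hydroxy step

The source may report more compounds than this note shows. Statements on the series, on what has been measured and on what is new or still open speak of the compounds shown alone.

Measured so far in a functional assay on K562 cells (Homo sapiens) for cytotoxicity, read by sulforhodamine B assay; on this read-out higher numbers stand for weaker inhibition and lower numbers for stronger inhibition:
compound 1 `[N-]=[N+]=N[C@@H]1C(n2ccc(=O)[nH]c2=O)[Se][C@H](CO)[C@H]1O` gives > 100000 nM, which is a limit of the assay and not a number.
compound 2 `Cc1cn(C2[Se][C@H](CO)[C@@H](O)[C@@H]2N=[N+]=[N-])c(=O)[nH]c1=O` gives > 100000 nM, again a limit and not a number.
compound 3 `[N-]=[N+]=N[C@@H]1C(n2ccc(N)nc2=O)[Se][C@H](CO)[C@H]1O` gives 62300 nM.

Within the data shown here, compound 3 thus stands as the only compound with a number in this assay. The other two sit at the limit of > 100000 nM in this assay, at which 2 of the 3 values shown sit. Among the measured compounds shown here, the only step between two measured compounds that differ in a single place, a step that the two limits leave unreadable from compound 1 to compound 2, is a methyl in place of hydrogen on an aromatic carbon, and its size is not readable from the two limits.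

Compound 4 `Nc1ccn(C2[Se][C@H](CO)[C@@H](O)[C@@H]2O)c(=O)n1` is not yet measured. It differs from compound 3 by hydroxy in place of azido on a saturated ring carbon. For the measured compounds named here, no measured step touches this change, and the single step that exists gives no readable size, so nothing bears on direction or size here. Compound 3 lies near the limit, so compound 4 is expected near it too, and the expected step of a 1.3-fold higher number from compound 3 to compound 4 (0.11 log units; within the scatter) is taken as one of no size beyond the scatter. The estimate for compound 4 in this assay is 80000 nM, with a range of 20000 nM to 300000 nM, and a real chance that only a limit is reported.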

Compound 4, half-maximal inhibitory concentration: 86600 nM
Compound 4: middle estimate off by 1.1-fold (0.03 log units), on the low side; low and high end bracket the measured number.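

In this assay, among these compounds, hydroxy in place of azido on this saturated ring carbon gives a 1.4-fold higher number from compound 3 to compound 4 (0.14 log units; within the scatter) and this is the first step with a number on both sides. The change takes out a group of 3 heavy atoms with 0 hydrogen-bond donors and puts in one of 1 heavy atom with 1 hydrogen-bond donor, yet on the core of compound 3 this read-out does not separate the two groups at this position, two ring bonds from the ring selenium. The earlier step cannot be read, so the series still holds no step beyond the scatter, and much of it rests on a limit: the limit of > 100000 nM in this assay, at which 2 of the 4 values shown sit.

As far as these compounds go, whether another group on this ring carbon, such as an amine, a fluorine or a methoxy group, would shift the number beyond the scatter stays open. Also open, from the compounds shown here alone, is whether hydroxy in place of azido would give a readable number on the cores of compound 1 and compound 2, which so far offer only limits.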